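Phenyl in Place of Methyl on a Carbonyl Carbon

The source may hold more compounds than are shown below. What is called first, only, known or untested is meant among the compounds shown, and "the series" means these compounds.

Three measured compounds share one core and differ only in the group at the end of a double-bonded chain. In an ADME assay on HEK293 cells (Homo sapiens) for cytotoxicity, with a stated time of 72 h (a lower number here means that less compound is needed, a higher number that more compound is needed for the effect), compound 1 `COc1ccc(/C=C/[C@@](C)(/C=C/c2ccc(O)c(/C=C/C#N)c2)CCC=C(C)C)cc1` gives > 36600 nM as a limit of the assay and not a number. Compound 2 `COc1ccc(/C=C/[C@@](C)(/C=C/c2ccc(O)c(/C=C/C(=O)OCc3ccccc3)c2)CCC=C(C)C)cc1` gives > 36600 nM and this too is only a limit. For the measured compounds named here, compound 3 `COc1ccc(/C=C/[C@@](C)(/C=C/c2ccc(O)c(/C=C/C(C)=O)c2)CCC=C(C)C)cc1` carries an acetyl group and gives 14600 nM as the only true number of the three.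

The change to compound 4 `COc1ccc(/C=C/[C@@](C)(/C=C/c2ccc(O)c(/C=C/C(=O)c3ccccc3)c2)CCC=C(C)C)cc1` is phenyl in place of methyl on a carbonyl carbon with phenyl in place of methyl on a carbonyl carbon, which turns acetyl to benzoyl.

Going by the values given here, two measured steps bear on this change. One is an at least 2.5-fold lower number from compound 1 to compound 3 (0.39 log units; beyond the scatter) and the other is an at least 2.5-fold lower number from compound 2 to compound 3 (0.39 log units; beyond the scatter) on the same carbonyl carbon, which makes it the closer guide. On these data alone, both begin at the limit of > 36600 nM in this assay, at which 2 of the 3 values shown sit, so their full size stays unknown. Read backwards, the second step pairs the larger group with the higher number, but benzyloxy is not phenyl and one step is thin support. The expected step is a 1.4-fold higher number from compound 3 to compound 4 (0.14 log units; within the scatter) and it leans slightly upward, probably without leaving the scatter. Compound 4 is estimated at 20000 nM with an expected range from 8000 nM to 36600 nM in this estimate.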

Compound 4, half-maximal effective concentration: > 36600 nM
Compound 4: only a limit was reported; the forecaster's own chance of this, stated with the estimate: 30%; middle value at least 1.8-fold (0.26 log units) away from the limit.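

Placing phenyl instead of methyl on the carbonyl carbon gives an at least 2.5-fold higher number from compound 3 to compound 4 (0.39 log units; beyond the scatter) in this assay, so more compound is needed for the effect once acetyl becomes benzoyl. For the compounds shown here, the earlier step to compound 3 started from benzyloxy, whereas this one tests phenyl directly on the carbonyl carbon, and now methyl is the only one of the three groups there that gives a true number, while both ring-bearing groups, in compound 2 and compound 4, give only limits. The steps that join compound 4 to compound 1 and to compound 2 cannot be read, because both ends of each step sit at the same limit: the limit of > 36600 nM in this assay, at which 3 of the 4 values shown sit.

On these data alone, how far the true value of compound 4 lies past its limit remains unknown, so the step has a lower bound on its size but no upper one. As far as these compounds go, it also remains open whether the change follows from the ring itself or simply from more carbon on this carbonyl, a question that an ethyl group, a longer chain or a cyclohexyl ring at the same place could help to separate.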